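Three Limits and One Untested Amide

The source may hold more compounds than are shown below. What is called first, only, known or untested is meant among the compounds shown, and "the series" means these compounds.

Compound 1 `COC(=O)CC/C(C)=C/Cc1c(OC)c(C)c2c(c1OCC#CCN1CCN(c3ccc(C#N)cc3)CC1)C(=O)OC2`: > 50000 nM
Compound 2 `COC(=O)CC/C(C)=C/Cc1c(OC)c(C)c2c(c1OCC#CCN1CCN(C(c3ccc(F)cc3)c3ccc(F)cc3)CC1)C(=O)OC2`: > 50000 nM
Compound 3 `COC(=O)CC/C(C)=C/Cc1c(OC)c(C)c2c(c1OCC#CCN1CCN(C(c3ccccc3)c3ccc(Cl)cc3)CC1)C(=O)OC2`: > 50000 nM

In a functional assay on HT-29 cells (Homo sapiens) for inhibition, read by sulforhodamine B assay (a lower number here means a stronger inhibitor, a higher number a weaker inhibitor), compound 1 gives > 50000 nM, which is a limit of the assay and not a number. Within the data shown here, compound 2 and compound 3 also give only limits, so no exact potency is known for any compound so far. In compound 4 `COC(=O)CC/C(C)=C/Cc1c(OC)c(C)c2c(c1OCC#CCN1CCN(C(=O)C3COc4ccccc4O3)CC1)C(=O)OC2`, (2,3-dihydro-1,4-benzodioxin-2-yl)carbonyl stands in place of 4-cyanophenyl on an amine nitrogen in a ring: (2,3-dihydro-1,4-benzodioxin-2-yl)carbonyl in place of 4-cyanophenyl on an amine nitrogen in a ring. Among the measured compounds shown here, no measured pair differs in only one place, so no measured step shows how large such a change might be. For compound 4 no large gain over compound 1 is expected because of the limit of > 50000 nM in this assay, at which 3 of the 3 values shown sit. The expected step, a number no higher from compound 1 to compound 4 (the limit leaves the size open), is small and has no clear direction. Compound 4 is estimated at 50000 nM, within an expected range from 20000 nM to 100000 nM.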

Compound 4, half-maximal inhibitory concentration: > 50000 nM
Compound 4 ended at the assay's limit; the forecaster's own chance of this, stated with the estimate: 75%; the middle value lies on the limit itself.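

In this assay, compound 1 and compound 4 both give only limits and not numbers, so the step between them cannot be read. The compounds shown leave open whether any group on this ring nitrogen gives a measurable potency.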